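The compounds below may be only part of what the source reports. "The series", "measured", "known", "first", "only" and "open" are said of these compounds alone.

Compound 1, `CC(=O)C[C@H]1O[C@@H](On2cc(CN3C(=O)/C(=N\Nc4ccc(F)cc4)c4ccccc43)nn2)[C@H](OC(C)=O)[C@@H](OC(C)=O)[C@@H]1OC(C)=O`, and compound 2, `CC(=O)C[C@H]1O[C@@H](On2cc(CN3C(=O)/C(=N\Nc4cccc(Cl)c4)c4ccccc43)nn2)[C@H](OC(C)=O)[C@@H](OC(C)=O)[C@@H]1OC(C)=O`, share one core and differ only at the edge. In an ADME assay on Vero cells (Chlorocebus sabaeus) for cytotoxicity, read by fluorescence and resazurin assay, with a stated time of 3 days (a lower number here means that less compound is tolerated, a higher number that more compound is tolerated), compound 1 gives 68700 nM. Compound 2 carries the change (3-chlorophenyl in place of 4-fluorophenyl on an amine nitrogen), and in this assay compound 2 gives 117000 nM. The step of a 1.7-fold higher number from compound 1 to compound 2 (0.23 log units; within the scatter) is therefore one that cannot be told apart from repeat measurement.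

Compound 3, `CC1(C)O[C@H]2O[C@H](Cn3cc(CN4C(=O)/C(=N\Nc5ccc(F)cc5)c5ccccc54)nn3)[C@H](O)[C@H]2O1`, sits on a different core; how the core of compound 3 differs from the core of compound 1 is not broken down here. In this assay compound 3 gives 83800 nM, which sits within the scatter of both compound 1 and compound 2, so no order among the three can be claimed.

Compound 4, `CC1(C)O[C@H]2O[C@H](Cn3cc(CN4C(=O)/C(=N\Nc5cccc(Cl)c5)c5ccccc54)nn3)[C@H](O)[C@H]2O1`, is still to be measured. It is related to compound 3 by the change (3-chlorophenyl in place of 4-fluorophenyl on an amine nitrogen), the same change that turns compound 1 into compound 2, made at the same place. Because the earlier step of a 1.7-fold higher number from compound 1 to compound 2 (0.23 log units; within the scatter) stayed within the scatter, compound 4 is expected to stay close to compound 3 as well, with the step of a 1.4-fold higher number from compound 3 to compound 4 (0.14 log units; within the scatter) estimated in the same direction and of about the same size. On that basis the half-maximal cytotoxic concentration of compound 4 in this assay is estimated at 115000 nM, with the expected range running from 55000 nM to 230000 nM.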

Compound 4, half-maximal cytotoxic concentration: 70000 nM
Beside the measured number, compound 4's estimate is 1.6-fold (0.22 log units) above it, and the stated range covers the measured number.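

In this assay, the change from 4-fluorophenyl to 3-chlorophenyl on the core of compound 3 gives a 1.2-fold lower number from compound 3 to compound 4 (0.08 log units; within the scatter), so on this core too the change cannot be told apart from repeat measurement. Set beside the earlier step, the result on the two cores offers no sign that the core alters what this change does: the same change on two cores in this assay, a 1.7-fold higher number (0.23 log units; within the scatter) from compound 1 to compound 2 and a 1.2-fold lower number (0.08 log units; within the scatter) from compound 3 to compound 4, 2.0-fold (0.31 log units) apart, within the scatter of two such steps. Among the compounds shown here, this shows only that the change stayed within the scatter on both cores, and it does not show that the change has a direction on either core, nor that the opposite signs of the two steps mark a real reversal, and with only one pair on each core it gives no rule for cores beyond these two.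

What the compounds shown leave open is whether any other group on this amine nitrogen, such as an unsubstituted phenyl, a pyridyl ring or a phenyl ring carrying a carboxylic acid, would give a step that stands clear of the scatter and whether such a step would carry from one core to the other. They also leave open whether the change from 4-fluorophenyl to 3-chlorophenyl would stay this small in a different cell line or over a different exposure time.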